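Adding a hydroxy group to compound 1

The source may hold more compounds than are shown below. What is called first, only, known or untested is meant among the compounds shown, and "the series" means these compounds.

For the measured compounds named here, in a functional assay on ACHN cells (Homo sapiens) for inhibition (on this read-out higher numbers stand for weaker inhibition of growth and lower numbers for stronger inhibition of growth), compound 1 (`COc1ccc(-n2cnnc2-c2cc(OC)c(OC)c(OC)c2)cc1`) gives 4470 nM, the higher of the two numbers available so far. Compound 2 (`COc1cc(-c2nncn2-c2ccc(N(C)C)cc2)cc(OC)c1OC`) gives 204 nM. Compound 3 (`COc1ccc(-n2cnnc2-c2cc(OC)c(OC)c(OC)c2)cc1O`) has not yet been measured. It differs from compound 1 by hydroxy in place of hydrogen on an aromatic carbon, ortho to a methoxy group and meta to a large group.

Going by the values given here, only one measured step bears on this change, and only indirectly. That step, a 22-fold lower number from compound 1 to compound 2 (1.34 log units; beyond the scatter), is large and beyond the scatter, and it shows that the series can respond strongly to dimethylamino in place of methoxy on an aromatic carbon. Among the compounds with values here, it is a different change, however, and no measured compound carries a hydroxy group, so a single step sets neither the size nor the direction firmly. A moderate move toward stronger inhibition of growth is the working expectation, smaller than the measured step. The expected step is an 11-fold lower number from compound 1 to compound 3 (1.05 log units; beyond the scatter). Compound 3 is estimated at 400 nM in this assay, with an expected range of 60 nM to 2500 nM.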

Compound 3, concentration for 50% growth inhibition: 417 nM
Estimate against measurement, compound 3: 1.0-fold (0.02 log units) below; the measured number falls inside the stated range.
By their numbers in this assay, from the lowest: compound 2; then compound 3; then compound 1.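

In this assay hydroxy in place of hydrogen on an aromatic carbon, ortho to a methoxy group and meta to a large group, brings an 11-fold lower number from compound 1 to compound 3 (1.03 log units; beyond the scatter) and marks this position as one where the series responds strongly. For the compounds shown here, the only earlier step, a 22-fold lower number from compound 1 to compound 2 (1.34 log units; beyond the scatter) with dimethylamino in place of methoxy, changed a group already present; here the methoxy group stays, a hydrogen is replaced, and 1 heavy atom is enough for a large step. Nothing measured on these compounds accounts for the step, so it stands as an observation without an explanation.

The compounds shown leave open whether the step belongs to hydroxy itself or whether other small groups at this position, such as an amine, fluorine or a second methoxy group, would move the number in the same way and to the same extent. They also leave open whether hydroxy and dimethylamino would add up when carried together on the same aromatic ring, with dimethylamino in place of the methoxy group and hydroxy kept at this position.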